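Swapping a Naphthalene Arm for a Dimethoxybenzyl Arm

The compounds below may be only part of what the source reports. "The series", "measured", "known", "first", "only" and "open" are said of these compounds alone.

Measured compounds:
Compound 1, `O=S(=O)(NCCCNCc1cccc2ccccc12)c1cc(C(F)(F)F)cc(C(F)(F)F)c1`: 2700 nM
Compound 2, `CC(C)(C)c1ccc(CNCCNS(=O)(=O)c2cc(C(F)(F)F)cc(C(F)(F)F)c2)cc1`: 13000 nM

Of the compounds shown here, two have been tested in a functional assay on PANC-1 cells (Homo sapiens) for inhibition, read by MTT assay, with a stated time of 72 h; a lower number here means a stronger inhibitor of growth, a higher number a weaker inhibitor of growth. Compound 1 gives 2700 nM, the lower of the two numbers. Compound 2 gives 13000 nM, and the gap between the two is wider than the usual scatter. These two compounds differ in more than one place, so the gap cannot be attributed to any single change.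

Compound 3, `COc1ccc(CNCCCNS(=O)(=O)c2cc(C(F)(F)F)cc(C(F)(F)F)c2)cc1OC`, has not yet been measured. It differs from compound 1 in one place: 3,4-dimethoxyphenyl in place of naphthalen-1-yl on a saturated chain carbon bound to an amine nitrogen. The remainder of the molecule, the sulfonamide bearing two trifluoromethyl groups and the chain with its amine nitrogen, is unchanged.

Within the data shown here, no measured pair in this set isolates this change. Compound 2 shows that a different group on the amine-bearing carbon can raise the number in this assay well beyond the scatter, but it carries a second difference as well. The step from compound 1 to compound 3 is therefore expected to be a moderate move toward a higher number, a 2.2-fold higher number from compound 1 to compound 3 (0.35 log units; beyond the scatter). On that basis compound 3 is estimated to give 6000 nM in this assay, with a plausible range from 2500 nM to 15000 nM.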

Compound 3, concentration for 50% growth inhibition: 18000 nM
For compound 3 the middle estimate is 3.0-fold (0.48 log units) below the measured one; the whole stated range lies below it.
By their numbers in this assay, from the lowest: compound 1; then compounds 2 and 3 (each within the scatter of the next).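

In this assay, among these compounds, putting 3,4-dimethoxyphenyl in place of naphthalen-1-yl on a saturated chain carbon bound to an amine nitrogen gives a 6.7-fold higher number from compound 1 to compound 3 (0.82 log units; beyond the scatter), and this is the first comparison here in which a change in this position stands alone. The earlier pair differed in more than one place, whereas this step shows that the group at this position can, by itself, move the number by more than the usual scatter, with compound 1 the stronger inhibitor of growth of the two. The two groups have the same count of heavy atoms, so that count does not separate them; they differ in having two aromatic rings or one, and in carrying no oxygen or two oxygens with their two hydrogen-bond acceptors, but nothing available shows which of these differences accounts for the gap.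

Still open, going by these compounds, is whether the higher number goes with the loss of the second aromatic ring or with the arrival of the two methoxy groups. A plain phenyl group at this position on the same chain, or a naphthalene carrying methoxy groups, would help to tell those two changes apart.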